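Changing the Ether Group of Compound 1

This account rests on a few compounds, and the source may have more. Where it says the series, first, only, none or still open, it means among the compounds named here.

For the measured compounds named here, in a functional assay on KMS-11 cells (Homo sapiens) for antiproliferative activity, read by CellTiter-Glo, with a stated time of 72 h (a lower number here means a stronger inhibitor, a higher number a weaker inhibitor), compound 1 `COc1ccc(C(=O)N(Cc2ccncc2)Cc2cccc(OCCc3ccc(C)cc3)c2)cc1` gives 9100 nM and its only measured neighbour, compound 2 `COc1ccc(C(=O)N(Cc2ccncc2)Cc2cccc(OCCc3ccccc3)c2)cc1`, gives 16900 nM in the same test, so the two cannot be told apart. Compound 3 `COc1ccc(C(=O)N(Cc2ccncc2)Cc2cccc(OCC3CCCCC3)c2)cc1` differs from compound 1 by cyclohexyl in place of 4-methylbenzyl on a saturated chain carbon bound to an oxygen on an aromatic ring and no measurement covers this swap directly. Going by the values given here, the one measured step, hydrogen in place of methyl on an aromatic carbon, is a 1.9-fold higher number from compound 1 to compound 2 (0.27 log units; within the scatter) and bears only loosely on the swap, so no step beyond the scatter is expected in this assay for compound 3. The expected step is a 1.3-fold higher number from compound 1 to compound 3 (0.12 log units; within the scatter) by this estimate. The estimate for compound 3 is 12000 nM with an expected range from 5000 nM to 30000 nM in this test.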

Compound 3, half-maximal inhibitory concentration: 19700 nM
Estimate against measurement, compound 3: 1.6-fold (0.22 log units) below; measured number inside the range.
By their numbers in this assay, from the lowest: compounds 1, 2 and 3 (each within the scatter of the next, the first and the last beyond it).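

In this assay, for the compounds shown here, cyclohexyl in place of 4-methylbenzyl gives a 2.2-fold higher number from compound 1 to compound 3 (0.34 log units; beyond the scatter) and is the first step at this place to pass the scatter, though only modestly. Cyclohexyl in place of benzyl gives a 1.2-fold higher number from compound 2 to compound 3 (0.07 log units; within the scatter) and so shows no clear change, which means that a non-aromatic ring can be told apart only from the methyl-bearing aromatic group. Nothing measured here explains either step. Still open, going by these compounds, is whether the ring or the chain joining it to the oxygen matters more, as both differ between these compounds. On these data alone, how an amine or a longer chain would behave at this place is also open.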